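The compounds below may be only part of what the source reports. "The series", "measured", "known", "first", "only" and "open" are said of these compounds alone.

Compound 1, `O=C(NCc1ccc(S(=O)(=O)c2ccccc2)cc1)N1Cc2cccnc2C1`, gives > 2000 nM in a functional assay on A2780 cells (Homo sapiens) for cytotoxicity, read by sulforhodamine B assay, with a stated time of 72 h; a higher number here means a weaker inhibitor, a lower number a stronger inhibitor; this is a limit of the assay, not a number.
Compound 2, `O=S(=O)(c1ccccc1)c1ccc(CNS(=O)(=O)N2Cc3ccncc3C2)cc1`, gives > 2000 nM in this assay; this too is a limit.
Compound 3, `O=C(NCc1ccc(S(=O)(=O)C2CCC(F)(F)CC2)cc1)N1Cc2ccncc2C1`, gives 13 nM in this assay.

Among the measured compounds shown here, of the three compounds measured so far, compound 3 is the only one for which a number was obtained at all. For the measured compounds named here, the two others sit at the limit of > 2000 nM in this assay, at which 2 of the 3 values shown sit, so there is nothing to compare compound 3 against in terms of size, and no step between two measured compounds can be drawn. Compound 3 therefore stands alone as the sole reference point.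

Compound 4, `O=C(NCc1ccc(S(=O)(=O)N2CC3(CCOCC3)C2)cc1)N1Cc2ccncc2C1`, keeps the shared core of compound 3 and changes only the group attached to the sulfonyl sulfur: a group of 9 heavy atoms (7 carbon, 1 nitrogen, 1 oxygen; one four-membered non-aromatic ring with 1 hetero atom, one six-membered non-aromatic ring with 1 hetero atom) in place of a group of 8 heavy atoms (6 carbon, 2 fluorine; one six-membered non-aromatic ring of carbon only), on a sulfonyl sulfur.

Going by the values given here, with no measured step to lean on, the expectation for compound 4 must be cautious. The replacement is of comparable size but quite different in make-up, and the sulfonyl now carries a nitrogen rather than a carbon neighbour. Some loss of potency relative to compound 3 seems the more likely outcome, but a result within the scatter cannot be excluded. The step from compound 3 to compound 4 is expected to be a 4.6-fold higher number from compound 3 to compound 4 (0.66 log units; beyond the scatter). Compound 4 is therefore estimated at 60 nM, within a range from 15 nM to 400 nM.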

Compound 4, half-maximal inhibitory concentration: 10 nM
For compound 4 the middle estimate is 6.0-fold (0.78 log units) above the measured one, outside the stated range (below it).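

In this assay, the position on the sulfonyl sulfur whose other neighbour is an aromatic carbon now has its first readable step, a 1.3-fold lower number from compound 3 to compound 4 (0.11 log units; within the scatter). The 4,4-difluorocyclohexyl group, a six-membered ring of carbon only with two fluorine atoms, and the entering group, with its four-membered and six-membered rings that each hold a hetero atom, therefore give values within the scatter of each other, even though the entering group holds nitrogen and oxygen and has one hydrogen-bond acceptor where the group it replaces has none. Nothing shown here explains why these two different groups give values this close.

The compounds shown leave open how much further the group on the sulfonyl sulfur can be varied, for example to a morpholine, a simple dimethylamino group, or a ring bearing a carboxylic acid. Among the compounds shown here, with only this one step at this position, they also leave open whether the two groups would stay within the scatter of each other on a different shared core or in a different read-out.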